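Cyclopentyl Urea Analogue: Expected Antiproliferative Activity

A few compounds are considered here, and "the series" means these few. Any claim that something is new, unique, unknown or untested is made for them only; others in the source may bear on it.

Measured compounds:
- compound 1 `CCCC(=O)Nc1ccc(S(=O)(=O)Oc2ccccc2C(C)C)cc1`: 4900 nM
- compound 2 `CCNC(=O)Nc1ccc(S(=O)(=O)Oc2ccccc2C(C)C)cc1`: 1100 nM
- compound 3 `CCCNC(=O)Nc1ccc(S(=O)(=O)Oc2ccccc2C(C)C)cc1`: 6300 nM

All three share the same core, an isopropylphenyl sulfonate ester bound to an aniline, and differ only in the group on that aniline nitrogen. In a functional assay on HT-29 cells (Homo sapiens) for antiproliferative activity, read by sulforhodamine B assay, with a stated time of 48 h (a higher number here means a weaker inhibitor, a lower number a stronger inhibitor), compound 3 gives the highest number of the three: compared with compound 1 it is a 1.3-fold higher number from compound 1 to compound 3 (0.11 log units; within the scatter), and compared with compound 2 it is a 5.7-fold higher number from compound 2 to compound 3 (0.76 log units; beyond the scatter).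

Compound 4 `CC(C)c1ccccc1OS(=O)(=O)c1ccc(NC(=O)NC2CCCC2)cc1` follows from compound 3 by one change: cyclopentyl in place of propyl on an amide-type nitrogen. Among the compounds with values here, no measured step makes exactly this change, so the expectation rests on indirect evidence. The step of a 5.7-fold higher number from compound 2 to compound 3 (0.76 log units; beyond the scatter) shows that a change in the alkyl group on the urea nitrogen can move the number beyond the scatter, while a 1.3-fold higher number from compound 1 to compound 3 (0.11 log units; within the scatter) shows that other changes at this position stay within it. A modest step in either direction is therefore possible, and the direction cannot be read from the data. The estimate for compound 4 is set close to compound 3, expected as a 1.4-fold lower number from compound 3 to compound 4 (0.15 log units; within the scatter), giving 4500 nM with a range from 1200 nM to 16000 nM.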

Compound 4, half-maximal inhibitory concentration: 7400 nM
Compound 4: the middle estimate sits 1.6-fold (0.22 log units) below what was measured; the range from low to high includes it.
By their numbers in this assay, from the lowest: compound 2; then compounds 1, 3 and 4 (each within the scatter of the next).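

In this assay, a cyclopentyl group, with its five-membered ring of carbon only, can take the place of propyl on this amide-type nitrogen with no change beyond the scatter (a 1.2-fold higher number from compound 3 to compound 4 (0.07 log units; within the scatter)). Compound 4 also stays within the scatter of the non-urea compound (a 1.5-fold higher number from compound 1 to compound 4 (0.18 log units; within the scatter)), but it lies well apart from the ethyl urea (a 6.7-fold higher number from compound 2 to compound 4 (0.83 log units; beyond the scatter)), so among the three ureas shown, only the ethyl group of compound 2 stands apart, while the propyl and cyclopentyl groups do not differ. No available evidence bears on what lies behind this result.

The compounds shown leave open how a methyl group or a cyclopropyl ring would read at this nitrogen. They also leave open whether a six-membered cyclohexyl ring would match cyclopentyl.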